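Shortening the Thioether Chain and Adding Bromine

A few compounds are considered here, and "the series" means these few. Any claim that something is new, unique, unknown or untested is made for them only; others in the source may bear on it.

Measured so far:
compound 1 `O=C(O)Cn1c(SCCc2ccccc2)nc2ccccc21`: 881 nM
compound 2 `CCOC(=O)CCCCSc1nc2ccccc2n1CC(=O)O`: 2360 nM

In an assay on HEK293 cells for displacement of a labelled ligand from prostaglandin D2 receptor 2 (Homo sapiens) (on this read-out higher numbers stand for weaker inhibition and lower numbers for stronger inhibition), compound 1 has the lower of the two numbers, the other being compound 2 with a 2.7-fold higher number from compound 1 to compound 2 (0.43 log units; beyond the scatter). Compound 3 `O=C(O)Cn1c(SCc2ccccc2Br)nc2ccccc21` differs from compound 1 by 2-bromophenyl in place of benzyl on a saturated chain carbon bound to a sulfur. Among the measured compounds shown here, the one measured step does not alter the same part: it swaps the phenyl for an ester-bearing chain, and counted as modest. With nothing closer to go on, compound 3 is expected to stay near compound 1, the step of a 1.0-fold higher number from compound 1 to compound 3 (0.01 log units; within the scatter) being within the scatter. The estimate for compound 3 is 900 nM, between 300 nM and 2700 nM.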

Compound 3, half-maximal inhibitory concentration: 580 nM
Compound 3: the middle estimate sits 1.6-fold (0.19 log units) above what was measured, within the range that was stated.
By their numbers in this assay, from the lowest: compounds 3 and 1 (each within the scatter of the next); then compound 2.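

In this assay, putting 2-bromophenyl in place of benzyl on a saturated chain carbon bound to a sulfur gives a 1.5-fold lower number from compound 1 to compound 3 (0.18 log units; within the scatter), so compound 1 and compound 3 cannot be told apart on this read-out. This position therefore tolerates this change, including the entry of a bromine, without a shift beyond the scatter. The swap is a single step, so the share of the bromine alone cannot be read from it.

On these data alone, whether an amine or a longer chain in this place would shift the number remains open. Nothing on hand explains this result.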